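A few compounds are considered here, and "the series" means these few. Any claim that something is new, unique, unknown or untested is made for them only; others in the source may bear on it.

In a functional assay on the whole organism for inhibition, with Rattus norvegicus as the target, read by paw edema, at a dose of 100 mg/kg by the oral route (a higher number here means more inhibition at the dose given (going by the name of the read-out), a lower number less inhibition), compound 3 `Cc1ccccc1NC(=O)c1c(O)c2cccnc2n(-c2ccccc2)c1=O` gives 11.7%. Two measured companions share its core. Compound 1 `Cc1cccc(NC(=O)c2c(O)c3cccnc3n(-c3ccccc3)c2=O)c1` gives 14.2%, and compound 2 `O=C(Nc1cccc(Cl)c1)c1c(O)c2cccnc2n(-c2ccccc2)c1=O` gives 7.6%. Compound 3 thus sits among three numbers that lie close together: the step of a number 2.5 percentage points lower from compound 1 to compound 3 (within the scatter) and the step of a number 4.1 percentage points higher from compound 2 to compound 3 (within the scatter) are both within the scatter, so none of the three can be told apart from the others on these numbers.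

The unmeasured compound 4 `COc1ccccc1NC(=O)c1c(O)c2cccnc2n(-c2ccccc2)c1=O` differs from compound 3 in a single place: methoxy in place of methyl on an aromatic carbon. The closest guide is the step of a number 6.6 percentage points lower from compound 1 to compound 2 (within the scatter), which also swaps one small group for another on an aromatic carbon of that ring and stays within the scatter; the steps that exchange one substituted phenyl group for another on the amide-type nitrogen are equally small. No measured change on this ring has moved the number beyond the scatter, so the step of a number 0.7 percentage points lower from compound 3 to compound 4 (within the scatter) is expected to be small as well. Compound 4 is therefore expected to give about 11% in this assay, somewhere between 2% and 21%.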

Compound 4, a percentage reported as inhibition, in the whole organism at one dose (the size of the read-out at that dose, not a potency): 8.1%
Estimate against measurement, compound 4: 2.9 percentage points above; the measured number falls inside the stated range.
By their numbers in this assay, from the lowest: compounds 2, 4, 3 and 1 (each within the scatter of the next).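

In this assay, putting methoxy in place of methyl on this aromatic carbon, ortho to a large group, adds an oxygen and a hydrogen-bond acceptor, yet a number 3.6 percentage points lower from compound 3 to compound 4 (within the scatter). This position has therefore now carried two different groups with no difference that can be read, and the new compound also stays close to the two with a substituent elsewhere on the phenyl ring: a number 0.5 percentage points higher from compound 2 to compound 4 (within the scatter), and a number 6.1 percentage points lower from compound 1 to compound 4 (within the scatter). No measurement is available to explain why these steps are small.

Still open, going by these compounds, is whether an amine or a carboxylic acid on this aromatic carbon, or a longer chain on the oxygen of the methoxy, would move the number beyond the scatter. Also open, on these data alone, is whether any change to this phenyl group can do so at all.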